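Swapping the Furan for a Dichlorophenyl Group

The source may report more compounds than this note shows. Statements on the series, on what has been measured and on what is new or still open speak of the compounds shown alone.

In a functional assay on L1210 cells (Mus musculus) for cytotoxicity, read by MTT assay, with a stated time of 24 h (a higher number here means a weaker inhibitor, a lower number a stronger inhibitor), compound 1 (`COc1cc(C(=O)/C=C/c2ccc(F)cc2)cc(OC)c1OC`) gives 46500 nM, and compound 2 (`COc1cc(C(=O)/C=C/c2ccc(C)o2)cc(OC)c1OC`) gives 46500 nM, so the two stand level. The next structure, compound 3 (`COc1cc(C(=O)/C=C/c2cc(Cl)cc(Cl)c2)cc(OC)c1OC`), carries 3,5-dichlorophenyl in place of 5-methylfuran-2-yl on a double-bonded chain carbon bound to a double-bonded chain carbon. For the measured compounds named here, only one measured step bears on this change, and it concerns the same place on the chain. That step, no change at the digits printed from compound 1 to compound 2 (within the scatter), exchanged 4-fluorophenyl for 5-methylfuran-2-yl and stayed within the scatter. It offers no sign that this assay responds to a change of group at this place. Going by the values given here, it is still thin evidence, since no measured compound carries two chlorines and the data give no direction for such a group. No step beyond the scatter is therefore expected. The expected change is a 1.2-fold lower number from compound 2 to compound 3 (0.09 log units; within the scatter), a small estimated step that stays within the scatter. For compound 3 the estimated value is 38000 nM, with an expected range from 15000 nM to 80000 nM.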

Compound 3, half-maximal inhibitory concentration: 44000 nM
Compound 3: the middle estimate sits 1.2-fold (0.06 log units) below what was measured; the measured number falls inside the stated range.
By their numbers in this assay, from the lowest: compounds 3, 1 and 2 (each within the scatter of the next).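

In this assay the exchange of 5-methylfuran-2-yl for 3,5-dichlorophenyl gives a 1.1-fold lower number from compound 2 to compound 3 (0.02 log units; within the scatter) and the exchange of 4-fluorophenyl for the same group gives a 1.1-fold lower number from compound 1 to compound 3 (0.02 log units; within the scatter) so neither step leaves the scatter. Until now this position rested on a single exchange, whereas three different groups on a double-bonded chain carbon bound to a double-bonded chain carbon now stand within the scatter of one another. The flat result also extends to a change in which a five-membered aromatic ring with 1 hetero atom and 1 hydrogen-bond acceptor gives way to a six-membered aromatic ring of carbon only, with two chlorine atoms and no hydrogen-bond acceptor. Nothing given here accounts for this lack of response.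

On these data alone, all three groups are aromatic rings without a hydrogen-bond donor or a net charge, so it remains open whether an amine, a carboxylic acid or a saturated ring at this place would move the number beyond the scatter. The three compounds also share the rest of their structure, which leaves open how this assay would respond to a change elsewhere on the shared core, such as replacing a methoxy group with a hydroxyl.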